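Swapping Isopropyl for Methoxy on a Shared Core

The source may report more compounds than this note shows. Statements on the series, on what has been measured and on what is new or still open speak of the compounds shown alone.

Three measured compounds share one core and differ only in the group that sits on one aromatic carbon. In an ADME assay on MT4 cells (Homo sapiens) for cytotoxicity, read by MTT assay (on this read-out higher numbers stand for lower toxicity in this test and lower numbers for higher toxicity in this test), compound 1 `S=C(Nc1cccc(Cl)c1)OCCc1ccccn1` gives 47000 nM. Compound 2 `CC(C)c1ccc(NC(=S)OCCc2ccccn2)cc1` gives 45000 nM in this assay, the lowest of the two plain numbers, with compound 1 as its nearest neighbour, within the usual scatter. Compound 3 `Fc1ccc(NC(=S)OCCc2ccccn2)cc1` reaches only a limit of the test, > 100000 nM, which is not a number but the highest concentration that this assay reports (the limit of > 100000 nM in this assay, at which 1 of the 3 values shown sits). Among the measured compounds shown here, the one measured step is an at least 2.2-fold higher number from compound 2 to compound 3 (0.34 log units; beyond the scatter), a swap of a small group for the isopropyl.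

Compound 4 `COc1ccc(NC(=S)OCCc2ccccn2)cc1` is not yet measured. It differs from compound 2 by methoxy in place of isopropyl on an aromatic carbon. For the measured compounds named here, because the only comparable step, an at least 2.2-fold higher number from compound 2 to compound 3 (0.34 log units; beyond the scatter), gave a higher number when a smaller group replaced the isopropyl, a step of similar kind is expected here, namely a 1.6-fold higher number from compound 2 to compound 4 (0.19 log units; within the scatter). Compound 4 is therefore estimated at 70000 nM in this assay, with a range from 35000 nM to 150000 nM.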

Compound 4, half-maximal cytotoxic concentration: 48000 nM
Compound 4: the middle estimate sits 1.5-fold (0.16 log units) above what was measured, within the range that was stated.
By their numbers in this assay, from the lowest: compounds 2, 1 and 4 (each within the scatter of the next). At a limit, above all of these: compound 3.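

In this assay, methoxy in place of isopropyl on this aromatic carbon gives no difference that can be told from the scatter: a 1.1-fold higher number from compound 2 to compound 4 (0.03 log units; within the scatter). Having fewer heavy atoms at this position is therefore not enough to shift the number, as compound 4 shows, whereas methoxy in place of fluoro gives an at least 2.0-fold lower number from compound 3 to compound 4 (0.31 log units; beyond the scatter), so the fluoro compound remains the one that stands apart. Compound 3 has a limit of the assay rather than a plain number: the limit of > 100000 nM in this assay, at which 1 of the 4 values shown sits.

The true size of the gap between fluoro and the other two groups stays open, and the compounds shown give no cause for it. Going by these compounds, it is also open whether an amine, a carboxylic acid or a longer chain on this aromatic carbon would behave like fluoro or like methoxy and isopropyl.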